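The source may report more compounds than this note shows. Statements on the series, on what has been measured and on what is new or still open speak of the compounds shown alone.

Compound 1 `O=C(CCCCC1CCSS1)Nc1ccccc1Cl`: 5.11%
Compound 2 `O=C(CCCCC1CCSS1)Nc1ccc(Cl)cn1`: "not active" (no number reported)
Compound 3 `O=C(CCCCC1CCSS1)Nc1ccc(Br)cn1`: "not active" (no number reported)

All three compounds were tested in a functional assay on KB cells (Homo sapiens) for inhibition, read by MTT assay, with a stated time of 24 h, tested at 0.1 ug/mL; on this read-out higher numbers stand for more inhibition of growth at the one concentration tested and lower numbers for less inhibition of growth. Compound 3 has no single number on this read-out, being reported as "not active" (no number reported). Compound 2 received the same verdict, "not active" (no number reported). The only figure in the set belongs to compound 1, at 5.11%, so the three give little to work from. Among the measured compounds shown here, no measured pair isolates a single change, and none of the three lacks the five-membered non-aromatic ring.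

Compound 4 `O=C(CCCCC(S)CCS)Nc1ccc(Br)cn1` keeps the rest of compound 3 and differs in one place: a group of 5 heavy atoms (3 carbon, 2 sulfur; no ring) in place of a group of 5 heavy atoms (3 carbon, 2 sulfur; one five-membered non-aromatic ring with 2 hetero atoms), on a saturated chain carbon, four bonds along the chain from a carbonyl carbon. The sulfur atoms remain, but the ring is gone and hydrogen-bond donors enter. For the measured compounds named here, the data hold no measured compound with this open chain, so the size of the step cannot be read from them. Going by the values given here, with compound 3 at "not active" (no number reported), and compound 1 at 5.11% as the only number, a small upward step in this assay is expected, quite possibly none beyond the scatter, and a second report without a number would be no surprise. For compound 4 the estimated value is 8%, with an expected range of 0% to 30%.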

Compound 4, percent growth inhibition at one concentration: "not active" (no number reported)
Compound 4: no number reported, and the estimate cannot be compared.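

In this assay compound 3 stands at "not active" (no number reported) and compound 4 at "not active" (no number reported) and so no step can be read between them. Nothing measured here bears on this result. The compounds shown leave open whether replacing the five-membered non-aromatic ring with the open 1,3-disulfanylpropyl group changes growth inhibition at all.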